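A few compounds are considered here, and "the series" means these few. Any claim that something is new, unique, unknown or untested is made for them only; others in the source may bear on it.

Compound 2 `Cc1ccc(S(=O)(=O)c2cnc3ccc(F)cc3c2N2CCC(C)CC2)cc1Cl` gives 91% in an assay on isolated protein for displacement of a labelled ligand from metabotropic glutamate receptor 5 (Homo sapiens), with a stated time of 60 min, tested at 1 uM (a higher number here means more inhibition at the concentration tested (going by the name of the read-out), a lower number less inhibition), the highest of the two numbers; compound 1 `CC1CCN(c2c(S(=O)(=O)c3ccc(Cl)cc3)cnc3ccc(F)cc23)CC1` stands nearest with 80%, and the step of a number 11 percentage points higher from compound 1 to compound 2 (beyond the scatter) lies beyond the scatter. Compound 3 `COc1ccc(S(=O)(=O)c2cnc3ccc(F)cc3c2N2CCC(C)CC2)cc1Cl` differs from compound 2 by methoxy in place of methyl on an aromatic carbon. For the measured compounds named here, no measured step touches this group: the single known step changes a different part of the molecule, so it offers no direct guide. The step of a number 6 percentage points lower from compound 2 to compound 3 (within the scatter) that is expected is therefore one not beyond the scatter. Compound 3 is estimated at 85%, between 65% and 98%.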

Compound 3, a percentage reported as inhibition, at one concentration (the size of the read-out at that concentration, not a potency): 82%
Compound 3: middle estimate off by 3 percentage points, on the high side; low and high end bracket the measured number.
By their numbers in this assay, from the lowest: compounds 1, 3 and 2 (each within the scatter of the next, the first and the last beyond it).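

For the compounds shown here, on the aromatic carbon ortho to the chloro group, methoxy in place of methyl brings a number 9 percentage points lower from compound 2 to compound 3 (within the scatter) in this assay, the first view of a change at this position. The 3-chloro-4-methoxyphenyl group also brings a number 2 percentage points higher from compound 1 to compound 3 (within the scatter), so compound 3 cannot be told apart from either neighbour, and the step from 4-chlorophenyl no longer lies beyond the scatter with methoxy in place of methyl. Nothing available explains these steps. From the compounds shown here alone, whether an amine, a hydroxyl or a longer chain such as ethoxy at this carbon would fare likewise remains open.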